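A few compounds are considered here, and "the series" means these few. Any claim that something is new, unique, unknown or untested is made for them only; others in the source may bear on it.

In a physicochemical assay for lipophilicity, at pH 7.4 (a higher number here means a more lipophilic compound, a lower number a more polar compound), three compounds sharing one core have been measured: compound 1 `C[C@H]1C(=O)N(C)C=Cc2ccccc21` gives 4.3, compound 2 `CCc1ccc2c(c1)C=CN(C)C(=O)[C@@H]2C` gives 5.9 and compound 3 `COCCOc1ccc2c(c1)C=CN(C)C(=O)[C@@H]2C` gives 4. Compound 3 thus stands level with one neighbour and well under the other: 2-methoxyethoxy in place of hydrogen gives a number 0.30 log units lower from compound 1 to compound 3 (within the scatter), and in place of ethyl it gives a number 1.90 log units lower from compound 2 to compound 3 (beyond the scatter).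

Compound 4 `C[C@H]1C(=O)N(C)C=Cc2cc(OC(CO)CO)ccc21` differs from compound 3 in one place, on an oxygen on an aromatic ring: 2-hydroxy-1-(hydroxymethyl)ethyl in place of 2-methoxyethyl on an oxygen on an aromatic ring. The change adds hydrogen-bond donors. Going by the values given here, no measured step exchanges these two chains, so the evidence is indirect. The nearest guides are the large a number 1.90 log units lower from compound 2 to compound 3 (beyond the scatter) and the equally large a number 1.60 log units higher from compound 1 to compound 2 (beyond the scatter), which show that a change at this place can move this assay well beyond the scatter. Among the compounds with values here, a clear downward step is therefore expected, smaller than the one ending at compound 3. The expected step is a number 1.00 log units lower from compound 3 to compound 4 (beyond the scatter). Compound 4 is estimated at 3, with an expected range from 2.4 to 3.6.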

Compound 4, distribution coefficient: 1.3
Beside the measured number, compound 4's estimate is 1.70 log units above it; measured number outside the range, below it.
By their numbers in this assay, from the lowest: compound 4; then compounds 3 and 1 (each within the scatter of the next); then compound 2.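

In this assay, the group on this oxygen on an aromatic ring turns out to matter greatly: 2-hydroxy-1-(hydroxymethyl)ethyl in place of 2-methoxyethyl gives a number 2.70 log units lower from compound 3 to compound 4 (beyond the scatter) even though the earlier chain had stayed within the scatter of hydrogen. Measured against the same parent, 2-hydroxy-1-(hydroxymethyl)ethoxy in place of hydrogen gives a number 3.00 log units lower from compound 1 to compound 4 (beyond the scatter) and in place of ethyl gives a number 4.60 log units lower from compound 2 to compound 4 (beyond the scatter), the largest step in this set. Nothing available here explains the size of these steps.

The compounds shown leave open whether a single hydroxyl, as in a 2-hydroxyethyl chain on the same oxygen, would produce a step of similar size. They also leave open how an amine or a carboxylic acid at the end of this chain would read.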